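Halogen swap on the anilino ring of compound 2

The source may report more compounds than this note shows. Statements on the series, on what has been measured and on what is new or still open speak of the compounds shown alone.

The series is followed in a functional assay on PC-3 cells (Homo sapiens) for inhibition; a lower number here means a stronger inhibitor, a higher number a weaker inhibitor. Compound 1 `c1ccc(Nc2cccc(-c3nc4ccccc4s3)c2)nc1` gives 4800 nM. Among the compounds with values here, compound 2 `CCn1c(=O)/c(=C2\Sc3ccccc3N2C)s/c1=C\c1ccncc1Nc1ccccc1F` gives 360 nM, the lowest of the three numbers so far, and compound 3 `CCn1c(=O)/c(=C2\Sc3ccc(OC)cc3N2C)s/c1=C\c1ccncc1Nc1ccccc1C` gives 370 nM, which lies within the scatter of compound 2. The number for compound 2 is clearly lower than that for compound 1; between compound 2 and compound 3 nothing separates the two.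

Compound 4 `CCn1c(=O)/c(=C2\Sc3ccccc3N2C)s/c1=C\c1ccncc1Nc1ccccc1Cl` is the next analogue, not yet measured. It differs from compound 2 in one place: chloro in place of fluoro on an aromatic carbon. Within the data shown here, no pair of measured compounds shows this exchange, so no measured step is available to lean on. The change is small in what is counted, and a step no larger than the scatter is expected in this assay , in either direction or none at all. The expected step is a 1.1-fold lower number from compound 2 to compound 4 (0.05 log units; within the scatter). For compound 4 the estimate is 320 nM, with a range from 130 nM to 800 nM.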

Compound 4, half-maximal inhibitory concentration: 780 nM
Compound 4: the middle estimate sits 2.4-fold (0.39 log units) below what was measured; the range from low to high includes it.
By their numbers in this assay, from the lowest: compounds 2 and 3 (each within the scatter of the next); then compound 4; then compound 1.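

In this assay, chloro in place of fluoro gives a 2.2-fold higher number from compound 2 to compound 4 (0.34 log units; beyond the scatter) and so shows that the aromatic carbon ortho to a large group is not indifferent to which halogen it carries. Within the data shown here, this is the first exchange made in one place only, and it gives the first measured reading for this position. Of the two halogens read here, fluoro gives the lower number, though the step is modest and rests on a single pair. No measurement at hand accounts for the difference between the two halogens.

From the compounds shown here alone, whether a bromo, a methoxy or an amine at this position would fall nearer compound 2 or compound 4 stays open. Also open, going by these compounds, is whether the same exchange gives a step of similar size when the shared core carries other groups.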